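Methyl on a Nitrogen: One Small Step, Made Twice

The source may hold more compounds than are shown below. What is called first, only, known or untested is meant among the compounds shown, and "the series" means these compounds.

Measured so far in a functional assay on the whole organism with Rattus norvegicus as the target; on this read-out higher numbers stand for an effect only at larger amounts of compound and lower numbers for an effect already at smaller amounts:
compound 1, `COc1cc(N)c(Cl)cc1C(=O)NCC1CCC(C)N1Cc1ccccc1`, gives 0.67 mg/kg
compound 2, `CNc1cc(OC)c(C(=O)NCC2CCC(C)N2Cc2ccccc2)cc1Cl`, gives 0.35 mg/kg
compound 3, `COc1cc(NC(C)=O)c(Cl)cc1C(=O)NC1CCN(Cc2ccccc2)C1`, gives 1.8 mg/kg

Compound 1 and compound 2 share one core; compound 3 has a different core, and the difference between the two cores is not broken down here. Compound 3 stands highest of the three in this assay, with its steps to compound 1 and to compound 2 both beyond the usual scatter.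

From compound 1 to compound 2 the change is methyl in place of hydrogen on a nitrogen on an aromatic ring. The step it made, a 1.9-fold lower number from compound 1 to compound 2 (0.28 log units; within the scatter), lies within the scatter, so the two values cannot be ranked against each other.

Compound 4, `COc1cc(N(C)C(C)=O)c(Cl)cc1C(=O)NC1CCN(Cc2ccccc2)C1`, is not yet measured. It differs from compound 3 by methyl in place of hydrogen on an amide-type nitrogen. This is the same kind of change as that from compound 1 to compound 2, but not the same: there the methyl entered on a nitrogen on an aromatic ring whose other neighbours are an aromatic carbon, here it enters on an amide-type nitrogen whose other neighbours are an aromatic carbon and a carbonyl carbon.

For compound 4 in this assay a step close to zero is expected, a 1.2-fold lower number from compound 3 to compound 4 (0.08 log units; within the scatter), because a 1.9-fold lower number from compound 1 to compound 2 (0.28 log units; within the scatter) stayed within the scatter. Going by the values given here, the estimate for compound 4 is therefore 1.5 mg/kg, with a range from 0.6 mg/kg to 3.6 mg/kg expected, the width reflecting that only one earlier example of this kind of change is available and that it sat on a different core.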

Compound 4, dose for half-maximal effect: > 30 mg/kg
Compound 4: no number, only a limit; the forecaster's own chance of this, stated with the estimate: 5%; middle value at least 20-fold (1.30 log units) from the limit.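

In this assay compound 4 gives > 30 mg/kg, which is a limit of the assay and not a number. Read against that limit, the new step is an at least 16-fold higher number from compound 3 to compound 4 (1.22 log units; beyond the scatter), so methyl in place of hydrogen on a nitrogen did not carry over from the core of compound 1 to the core of compound 3, where it enters on an amide-type nitrogen and not on a nitrogen on an aromatic ring: the same change on two cores in this assay, a 1.9-fold lower number (0.28 log units; within the scatter) from compound 1 to compound 2 and an at least 16-fold higher number (1.22 log units; beyond the scatter) from compound 3 to compound 4, at least 31-fold (1.50 log units) apart, beyond the scatter of two such steps The comparison does not show how large the step really is, nor whether the core or the kind of nitrogen accounts for the gap, as each core offers only a single pair and the two pairs differ in both respects, and the upper end of the measurement is reached here: the limit of > 30 mg/kg in this assay, at which 1 of the 4 values shown sits.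

The compounds shown leave open what the acetyl(methyl)amino group would do on the core of compound 1, and what methyl on a nitrogen on an aromatic ring, without the carbonyl, would do on the core of compound 3. They also leave open whether a longer chain such as ethyl on the amide-type nitrogen would read the same way as methyl.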